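Swapping the hydroxy of compound 1 for a carboxy group

The source may report more compounds than this note shows. Statements on the series, on what has been measured and on what is new or still open speak of the compounds shown alone.

In a functional assay on Hep 3B2 cells (Homo sapiens) for antiproliferative activity, read by MTT assay, with a stated time of 24 h, tested at 3.7 ug/mL (a higher number here means a stronger effect of the compound at the concentration tested, a lower number a weaker effect), compound 1, `CCOc1ccc2nc(C(=O)Nc3c(F)cc(-c4cccc(F)c4)cc3F)c(C)c(O)c2c1`, gives 1.56%, the lowest of the three numbers measured. Its two neighbours differ from it only at one ring position: compound 2, `Cc1c(C(=O)Nc2c(F)cc(-c3cccc(F)c3)cc2F)nc2ccc(OC(F)(F)F)cc2c1O`, gives 26.4%, and compound 3, `Cc1c(C(=O)Nc2c(F)cc(-c3cccc(F)c3)cc2F)nc2ccc(C(F)(F)F)cc2c1O`, gives 31.2%. The steps of a number 24.8 percentage points higher from compound 1 to compound 2 (beyond the scatter) and a number 29.6 percentage points higher from compound 1 to compound 3 (beyond the scatter) both lie beyond the scatter, while a number 4.8 percentage points higher from compound 2 to compound 3 (within the scatter) does not.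

Compound 4, `CCOc1ccc2nc(C(=O)Nc3c(F)cc(-c4cccc(F)c4)cc3F)c(C)c(C(=O)O)c2c1`, changes a different place on the shared core: carboxy in place of hydroxy on an aromatic carbon. For the measured compounds named here, none of the measured steps touches the hydroxy group, so no step here bears directly on this change; the only guidance is that compound 1 itself sits at the bottom of this small set and that changes elsewhere moved it modestly upward. With no direct evidence, the expected step of a number 6.4 percentage points higher from compound 1 to compound 4 (within the scatter) is small and likely within the scatter. Compound 4 is therefore estimated to give 8% in this assay, with a range from 0% to 35%.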

Compound 4, a percentage reported as inhibition, at one concentration (the size of the read-out at that concentration, not a potency): 26.5%
Estimate against measurement, compound 4: 18.5 percentage points below; low and high end bracket the measured number.
By their numbers in this assay, from the lowest: compound 1; then compounds 2, 4 and 3 (each within the scatter of the next).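

In this assay, the place opposite the ring nitrogen proves responsive: carboxy in place of hydroxy gives a number 24.9 percentage points higher from compound 1 to compound 4 (beyond the scatter) and so lifts the read-out by a modest step. For the compounds shown here, until now, only the ethoxy group of compound 1 had been varied, so this is the first sign that a second place on the shared core can change the result. No measurement at hand gives a reason for this rise.

On these data alone, it remains open whether the gain is particular to carboxy or would also appear with an amine, an amide or a methyl ester at this place. Also open, as far as these compounds go, is whether carboxy here would add to the effect of trifluoromethyl or trifluoromethoxy in place of the ethoxy group.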